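A few compounds are considered here, and "the series" means these few. Any claim that something is new, unique, unknown or untested is made for them only; others in the source may bear on it.

Working notes on the series

Three compounds have been run in a functional assay on the whole organism (strain Wistar) with Rattus norvegicus as the target, with a stated time of 4 h; a lower number here means that less compound is needed, a higher number that more compound is needed for the effect. Compound 1 `C=C(C)[C@@H]1CC=C(C)/C(=N/NC(=O)Nc2nnc(-c3ccc(OC)cc3)o2)C1` gives 300 mg/kg in this assay. Compound 2 `C=C(C)[C@@H]1CC=C(C)/C(=N/NC(=O)Nc2nnc(-c3ccc([N+](=O)[O-])cc3)o2)C1` differs from compound 1 by one change (nitro in place of methoxy on an aromatic carbon); in this assay compound 2 gives 300 mg/kg, and the step of no change at the digits printed from compound 1 to compound 2 (within the scatter) shows that the change left the read-out where it stood. Compound 3 `COc1ccc(-c2nnc(NC(=O)N/N=C/C/C(C)=C\CC=C(C)C)o2)cc1` has a different core from compound 1, and that difference is not broken down here; compound 3 gives 300 mg/kg in this assay, so compound 3 sits level with compound 1 and compound 2, all three within the usual scatter of one another.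

Compound 4 `CC(C)=CC/C=C(/C)C/C=N/NC(=O)Nc1nnc(-c2ccc([N+](=O)[O-])cc2)o1` has not yet been measured. It is related to compound 3 by the change (nitro in place of methoxy on an aromatic carbon), which is the same change, at the same kind of place, as that from compound 1 to compound 2. Among the measured compounds shown here, the only comparison on record for this change is no change at the digits printed from compound 1 to compound 2 (within the scatter), which was flat. With nothing else to lean on, the step from compound 3 to compound 4 is expected to be no change at the digits printed from compound 3 to compound 4 (within the scatter), because the earlier step of no change at the digits printed from compound 1 to compound 2 (within the scatter) was within the scatter and because compound 3 already gives 300 mg/kg, matching compound 1. The estimate for compound 4 in this assay is therefore 300 mg/kg, with a likely range from 150 mg/kg to 600 mg/kg.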

Compound 4, minimum effective dose: 300 mg/kg
Compound 4: the middle estimate sits on the measured number at the digits printed, and the stated range covers the measured number.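

In this assay the change from 4-methoxyphenyl to 4-nitrophenyl reads no change at the digits printed from compound 3 to compound 4 (within the scatter) on the second core, which repeats the flat result seen on the first. This does not show that the change is without effect in general: all four compounds sit at one level, so two flat steps give no guide to how the change would read on a core where the read-out is different, and they offer no account of why it is flat here. Within these four compounds alone, the change carries from one core to the other with no shift, and the two steps agree: the same change on two cores in this assay, no change at the digits printed (within the scatter) from compound 1 to compound 2 and no change at the digits printed (within the scatter) from compound 3 to compound 4, 1.0-fold (0.00 log units) apart, within the scatter of two such steps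

The compounds shown leave open whether another group on the aromatic carbon, such as an amine or a carboxylic acid, would move the minimum effective dose away from the level shared by all four, and whether a longer chain in place of the open chain of compound 3 would do so. With every value level, they also leave open which part of the structure, if any, governs the read-out in this series.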